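This account rests on a few compounds, and the source may have more. Where it says the series, first, only, none or still open, it means among the compounds named here.

Notes on the sulfonyl series in an assay on isolated protein for inhibition of Nicotinamide phosphoribosyltransferase (Homo sapiens), read by mass spectrometry, with stated times of 15 min and 30 min; a lower number here means a stronger inhibitor, a higher number a weaker inhibitor.

For the measured compounds named here, compound 2 `N#C/N=C(\NCc1ccc(S(=O)(=O)N2CC3CCC(C2)O3)cc1)Nc1ccncc1` gives 2.4 nM; it holds the lowest of the three numbers so far, though none of its steps to the others goes beyond the scatter. Compound 1 `N#C/N=C(\NCc1ccc(S(=O)(=O)c2ccccc2)cc1)Nc1ccncc1` gives 2.5 nM, and the step of a 1.0-fold lower number from compound 1 to compound 2 (0.02 log units; within the scatter) shows that exchanging the phenyl on the sulfonyl sulfur for the bicyclic amine leaves the read-out unchanged. Compound 3 `N#C/N=C(\NCc1ccc(S(=O)(=O)N2CC3CCC(C2)O3)cc1)Nc1cccnc1` gives 4.4 nM; the step of a 1.8-fold higher number from compound 2 to compound 3 (0.26 log units; within the scatter) stays within the scatter as well.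

Compound 4 `N#C/N=C(\NCc1ccc(S(=O)(=O)C2CCCCC2)cc1)Nc1ccncc1` is the next candidate. Relative to compound 2 the change is a group of 6 heavy atoms (6 carbon; one six-membered non-aromatic ring of carbon only) in place of a group of 8 heavy atoms (6 carbon, 1 nitrogen, 1 oxygen; one five-membered non-aromatic ring with 1 hetero atom, one six-membered non-aromatic ring with 2 hetero atoms), on a sulfonyl sulfur. Going by the values given here, only the step from compound 1 to compound 2 bears on this position, and it was flat, so the sulfonyl substituent has so far tolerated a carbocyclic aromatic ring and a bicyclic amine alike. Compound 3 does not inform this position. On that basis no step beyond the scatter is expected in this assay for compound 4; the estimated step is a 1.3-fold higher number from compound 2 to compound 4 (0.10 log units; within the scatter). For compound 4 the expected value in this assay is 3 nM, with a range from 1.2 nM to 8 nM.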

Compound 4, half-maximal inhibitory concentration: 5.4 nM
Estimate against measurement, compound 4: 1.8-fold (0.26 log units) below; the measured number falls inside the stated range.
By their numbers in this assay, from the lowest: compounds 2, 1, 3 and 4 (each within the scatter of the next, the first and the last beyond it).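

On the sulfonyl sulfur, this position is no longer flat in this assay: cyclohexyl gives a 2.3-fold higher number from compound 2 to compound 4 (0.35 log units; beyond the scatter), and against phenyl it gives a 2.2-fold higher number from compound 1 to compound 4 (0.33 log units; beyond the scatter), both modest but beyond the scatter, whereas the exchange of phenyl for the bicyclic amine gave only a 1.0-fold lower number from compound 1 to compound 2 (0.02 log units; within the scatter). Of the three groups on this sulfur, phenyl and the bicyclic amine stay within the scatter of each other and cyclohexyl alone stands apart from both, so the position tolerates change but does show a small difference between groups, with compound 4 still at 5.4 nM. Nothing measured here bears on why cyclohexyl parts from the other two groups.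

As far as these compounds go, it remains open whether a piperidine, a morpholine or a tert-butyl group on the sulfonyl sulfur would fall with cyclohexyl or with phenyl and the bicyclic amine, which would show how far this small difference extends. Also open is whether the cyclohexyl step holds with pyridin-3-yl in place of pyridin-4-yl on the amine nitrogen, since that exchange is shown only with the bicyclic amine.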